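This account rests on a few compounds, and the source may have more. Where it says the series, first, only, none or still open, it means among the compounds named here.

Series notes. In a functional assay on the whole organism (strain Swiss) with Mus musculus as the target, in the maximal electroshock model, with a stated time of 1 h, at a dose of 100 mg/kg by the intraperitoneal route (on this read-out higher numbers stand for a stronger effect at the one dose given and lower numbers for a weaker effect), compound 1 `CC(C(=O)N1CCN(c2ccccc2)CC1)N1C(=O)CCC1=O` gives 0%, compound 2 `CCC(C(=O)N1CCN(c2cccc(F)c2)CC1)N1C(=O)CCC1=O` gives 0% and compound 3 `CC(C(=O)N1CCN(c2ccc(F)cc2)CC1)N1C(=O)CCC1=O` gives 0%. Compound 2 stands level with compounds 1 and 3 at the digits shown. Going by the values given here, the only measured single-point step, no change at the digits printed from compound 1 to compound 3 (within the scatter), lies within the scatter. Compound 4 `CCC(C(=O)N1CCN(c2ccccc2F)CC1)N1C(=O)CCC1=O` differs from compound 2 in one place: 2-fluorophenyl in place of 3-fluorophenyl on an amine nitrogen in a ring. Among the compounds with values here, no measured step exchanges 3-fluorophenyl for 2-fluorophenyl, so the nearest guide is the flat run across compounds 1, 2 and 3, where a fluoro in place of hydrogen left the read-out unchanged. For compound 4 the expected step is no change at the digits printed from compound 2 to compound 4 (within the scatter), none beyond the scatter. Compound 4 is therefore estimated at 0%, in the range 0% to 10%.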

Compound 4, a percentage reported as activity, at one dose (the size of the read-out at that dose, not a potency): 0%
Estimate against measurement, compound 4: no gap at the digits printed; the measured number falls inside the stated range.
By their numbers in this assay, from the lowest: compounds 1, 2, 3 and 4 (each within the scatter of the next).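

In this assay, going by these compounds alone, 2-fluorophenyl in place of 3-fluorophenyl on the amine nitrogen in a ring gives no change at the digits printed from compound 2 to compound 4 (within the scatter), the first direct exchange between two fluorophenyl groups at this position. Moving the fluorine within the ring thus adds a second kind of change, alongside fluoro in place of hydrogen, that leaves the read-out flat at this one dose. Nothing available bears on why the read-out stays flat. Open, from the compounds shown here alone, is whether a larger group at this position, such as trifluoromethylphenyl or benzyl, would lift the read-out from this floor.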